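The source may hold more compounds than are shown below. What is called first, only, known or untested is meant among the compounds shown, and "the series" means these compounds.

Compound 1 `CCOC(=O)c1sc(-c2ccccn2)nc1N1CCC(NCc2ccc(OC)cc2)CC1`: 4.62%
Compound 2 `CCOC(=O)c1sc(-c2ccccn2)nc1N1CCC(NCc2ccc(Cl)c(Cl)c2)CC1`: 30.1%
Compound 3 `CCOC(=O)c1sc(-c2ccccn2)nc1N1CCC(NCc2ccc(Cl)cc2Cl)CC1`: 18.6%

In an ADME assay on RAW264.7 cells (Mus musculus) for cytotoxicity, read by MTT assay, with a stated time of 72 h, tested at 50 uM (a higher number here means more inhibition at the concentration tested (going by the name of the read-out), a lower number less inhibition), compound 1 stands lowest of the three numbers. The nearest is reached by a number 14 percentage points higher from compound 1 to compound 3 (beyond the scatter), the furthest by a number 25.5 percentage points higher from compound 1 to compound 2 (beyond the scatter). Compound 4 `CCOC(=O)c1sc(-c2ccncc2)nc1N1CCC(NCc2ccc(OC)cc2)CC1` differs from compound 1 by pyridin-4-yl in place of pyridin-2-yl on an aromatic carbon. For the measured compounds named here, no measured step bears on this part of the shared core: a number 25.5 percentage points higher from compound 1 to compound 2 (beyond the scatter), a number 14 percentage points higher from compound 1 to compound 3 (beyond the scatter) and a number 11.5 percentage points lower from compound 2 to compound 3 (beyond the scatter) all concern the group on the saturated chain carbon bound to the amine nitrogen, and the aromatic ring on the five-membered ring is the same in all three. The expected step is therefore a number 1.4 percentage points higher from compound 1 to compound 4 (within the scatter), none beyond the scatter. Compound 4 is estimated at 6%, within -6% to 18%.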

Compound 4, a percentage reported as inhibition, at one concentration (the size of the read-out at that concentration, not a potency): 16.1%
Compound 4: the middle estimate sits 10.1 percentage points below what was measured, and the stated range covers the measured number.
By their numbers in this assay, from the lowest: compound 1; then compounds 4 and 3 (each within the scatter of the next); then compound 2.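

In this assay, the ring on the five-membered aromatic ring proves to matter as well as the group on the saturated chain: pyridin-4-yl in place of pyridin-2-yl, with the same atoms joined differently, gives a number 11.5 percentage points higher from compound 1 to compound 4 (beyond the scatter) and so changes the read-out at this position. Nothing at hand explains this step. On these data alone, whether pyridin-3-yl or an unsubstituted phenyl at this place would move the number remains open. So does whether the same change would carry over to the 3,4-dichlorophenyl group of compound 2.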